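The compounds below may be only part of what the source reports. "The series", "measured", "known", "first", "only" and "open" are said of these compounds alone.

Compound 1, `COC(=O)c1nc(C)n(-c2ccccc2)n1`: > 100000 nM
Compound 2, `COC(=O)c1nc(C)n(-c2ccccc2C(F)(F)F)n1`: > 100000 nM

In a functional assay on NPC-TW01 cells (Homo sapiens) for inhibition, read by MTT assay, with a stated time of 72 h (on this read-out higher numbers stand for weaker inhibition of growth and lower numbers for stronger inhibition of growth), compound 1 gives > 100000 nM, which is a limit of the assay and not a measured number. Compound 2 likewise gives > 100000 nM, again only a limit. Going by the values given here, compound 1 thus stands at a limit alone, and the one further value shown is also a limit, as summed up by the limit of > 100000 nM in this assay, at which 2 of the 2 values shown sit.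

Compound 3, `COC(=O)c1nc(C)n(-c2cccc(Br)c2)n1`, differs from compound 1 by bromo in place of hydrogen on an aromatic carbon. Among the compounds with values here, the only measured step that bears on this change, from compound 1 to compound 2, was a step that the two limits leave unreadable from compound 1 to compound 2, so its size stays unknown. Nothing shown therefore points to a step in either direction in this assay beyond the scatter, and another limit is the most likely outcome. Compound 3 is accordingly expected to give about 100000 nM, with a range from 30000 nM to 300000 nM. This estimate corresponds to an expected step of a number no higher from compound 1 to compound 3 (the limit leaves the size open), within the scatter.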

Compound 3, concentration for 50% growth inhibition: > 100000 nM
Compound 3 ended at the assay's limit; the forecaster's own chance of this, stated with the estimate: 85%; the middle value sits exactly at the limit.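

In this assay no step can be read between compound 1 and compound 3, since both stand only at a limit: the limit of > 100000 nM in this assay, at which 3 of the 3 values shown sit. The compounds shown leave open whether any change to the shared core gives a measurable inhibition of growth, and how large the steps hidden behind these limits are.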